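A Larger Group on the Amide of Compound 2

The source may hold more compounds than are shown below. What is called first, only, known or untested is meant among the compounds shown, and "the series" means these compounds.

Within the data shown here, in an ADME assay on L02 cells (Homo sapiens) for antiproliferative activity, read by MTT assay, with a stated time of 48 h (a lower number here means a stronger inhibitor, a higher number a weaker inhibitor), compound 2 (`CCn1c(C(=O)N(C)CCO)ccc1C(CC)(CC)c1ccc(OCCC(O)(CC)CC)c(C)c1`) gives 2050 nM, the lower of the two numbers so far, while compound 1 (`CCn1c(C(=O)NC(CC(=O)O)C(=O)OC)ccc1C(CC)(CC)c1ccc(OCCC(O)(CC)CC)c(C)c1`) gives 7590 nM. Compound 3 (`CCn1c(C(=O)NC(CO)CCO)ccc1C(CC)(CC)c1ccc(OCCC(O)(CC)CC)c(C)c1`) differs from compound 2 on a carbonyl carbon: a group of 7 heavy atoms (4 carbon, 1 nitrogen, 2 oxygen; no ring) in place of a group of 5 heavy atoms (3 carbon, 1 nitrogen, 1 oxygen; no ring), on a carbonyl carbon. Among the measured compounds shown here, the only measured step that bears on this is a 3.7-fold lower number from compound 1 to compound 2 (0.57 log units; beyond the scatter), with a smaller group taking the place of a larger one. A larger group enters this time, so the expected step is a modest rise, a 1.7-fold higher number from compound 2 to compound 3 (0.23 log units; within the scatter), although a single step is thin evidence. For compound 3 the estimated value is 3500 nM, with a range of 1300 nM to 9500 nM.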

Compound 3, half-maximal inhibitory concentration: 3040 nM
Compound 3: middle estimate off by 1.2-fold (0.06 log units), on the high side, within the range that was stated.
By their numbers in this assay, from the lowest: compounds 2 and 3 (each within the scatter of the next); then compound 1.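

In this assay the larger group on the carbonyl carbon, with 3 hydrogen-bond donors against 1, leaves the number within the scatter (a 1.5-fold higher number from compound 2 to compound 3 (0.17 log units; within the scatter)), so this position tolerates that change without a clear loss. The group on the amide-type nitrogen still separates compound 3 from compound 1 (a 2.5-fold lower number from compound 1 to compound 3 (0.40 log units; beyond the scatter)), so compound 2 and compound 3 both stand apart from compound 1. No measurement shown here explains either step. Still open, on these data alone, is whether an amine or a ring on this carbonyl carbon would move the number beyond the scatter.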